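The compounds below may be only part of what the source reports. "The series", "measured", "known", "first", "only" and "open" are said of these compounds alone.

Compound 1, `Fc1ccc(-n2cc(-c3n[nH]c4cc(Cl)c(N[C@@H]5CCNC5)cc34)cn2)cc1`: 684 nM
Compound 2, `Cn1cc(-c2n[nH]c3ccc(N[C@@H]4CCNC4)cc23)cn1`: 20700 nM

Both were tested in an assay on HEK293 cells for displacement of a labelled ligand from tyrosine-protein kinase receptor UFO (Homo sapiens), read by NanoBRET, with a stated time of 2 h; on this read-out higher numbers stand for weaker inhibition and lower numbers for stronger inhibition. Compound 1 gives the lower of the two numbers, 684 nM, while compound 2 gives 20700 nM, a difference well beyond the usual scatter. Compound 3, `COc1ccc(-n2cc(-c3n[nH]c4cc(Cl)c(N[C@@H]5CCNC5)cc34)cn2)cc1`, has not yet been tested. It differs from compound 1 in one place: methoxy in place of fluoro on an aromatic carbon. Going by the values given here, no measured pair here shows what such a swap does, so no step beyond the scatter is expected in this assay, in either direction. Compound 3 is therefore expected to give about 700 nM, within 250 nM to 2000 nM. The expected step is a 1.0-fold higher number from compound 1 to compound 3 (0.01 log units; within the scatter).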

Compound 3, half-maximal inhibitory concentration: 374 nM
Estimate against measurement, compound 3: 1.9-fold (0.27 log units) above, and the stated range covers the measured number.
By their numbers in this assay, from the lowest: compounds 3 and 1 (each within the scatter of the next); then compound 2.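

In this assay, replacing fluoro with methoxy at this position gives a 1.8-fold lower number from compound 1 to compound 3 (0.26 log units; within the scatter), the first measured view of this change. On this read-out, the aromatic carbon para to a large group can therefore carry either 4-fluorophenyl's fluoro or 4-methoxyphenyl's methoxy, which adds a hydrogen-bond acceptor, without a step beyond the scatter. No supporting measurement here explains why the two compounds read alike. As far as these compounds go, what an amine or a carboxylic acid would do on this carbon remains open. So does whether a longer chain, such as butoxy, would stay within the scatter of compound 1.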